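Replacing the Pentyl Amide Tail: Toxicity Outlook for Compound 4

The source may hold more compounds than are shown below. What is called first, only, known or untested is meant among the compounds shown, and "the series" means these compounds.

Of the compounds shown here, three sharing one core have been tested in an ADME assay on CEM-SS cells (Homo sapiens) for cytotoxicity, read by XTT assay, with a stated time of 6 days; on this read-out higher numbers stand for lower toxicity in this test and lower numbers for higher toxicity in this test. Compound 1 `CCCC(=O)OCSc1ccccc1C(=O)NCCCCCCC(N)=O` gives 10.4 uM, the lowest of the three numbers and therefore the most toxic of the set. Compound 2 `CCCC(=O)OCSc1ccccc1C(=O)Nc1ccc(C(N)=O)cc1` gives 39 uM, and compound 3 `CCCC(=O)OCSc1ccccc1C(=O)OCC(N)=O` gives 82.1 uM; both gaps from compound 1 lie beyond the usual scatter. Compound 4 `CCCC(=O)OCSc1ccccc1C(=O)NCC(=O)NCC(N)=O` has not yet been measured. It differs from compound 1 in one place: (carbamoylmethyl)carbamoyl in place of 5-carbamoylpentyl on a saturated chain carbon bound to an amide-type nitrogen. Within the data shown here, no measured pair shows this exact change, so the expectation rests on the wider picture, in which both other side chains gave higher numbers than compound 1. A modest rise in the number is therefore expected, a 2.4-fold higher number from compound 1 to compound 4 (0.38 log units; beyond the scatter). Compound 4 is expected to give about 25 uM in this assay, within a range from 8 uM to 75 uM.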

Compound 4, half-maximal toxic concentration: > 100 uM
Compound 4: a limit, no number; the forecaster's own chance of this, stated with the estimate: 15%; at least 4.0-fold (0.60 log units) between middle value and limit.
By their numbers in this assay, from the lowest: compound 1; then compound 2; then compound 3. At a limit, above all of these: compound 4.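

In this assay, putting (carbamoylmethyl)carbamoyl in place of 5-carbamoylpentyl on a saturated chain carbon bound to an amide-type nitrogen gives an at least 9.6-fold higher number from compound 1 to compound 4 (0.98 log units; beyond the scatter), so this position clearly responds to the group it carries. On these data alone, for compound 4 the result is a limit, not a number, so the full size of the step stays unknown: the limit of > 100 uM in this assay, at which 1 of the 4 values shown sits. The compounds shown leave open whether the shorter chain or the amide inside the new group accounts for the change. They also leave open how a plain butyl chain ending in a carboxylic acid or an amine would read at this place.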